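The source may hold more compounds than are shown below. What is called first, only, known or untested is meant among the compounds shown, and "the series" means these compounds.

Of the compounds shown here, three sharing one core have been measured in an assay on isolated protein for inhibition of Amine oxidase [flavin-containing] A (Homo sapiens), read by fluorescence; a lower number here means a stronger inhibitor, a higher number a weaker inhibitor. Compound 1 `CCCCCC/C(C)=N/Nc1nc(-c2cccc(OC)c2)cs1` gives 1380 nM. Compound 2 `COc1cccc(-c2csc(N/N=C/c3cccs3)n2)c1` gives 458 nM, and compound 3 `CCC(CC)=NNc1nc(-c2cccc(OC)c2)cs1` gives 824 nM. For the measured compounds named here, of these three numbers the one for compound 1 stands highest; its gap to compound 3 lies within the scatter of repeated measurements, whereas its gap to compound 2 lies beyond it. Compound 4 `COc1cccc(-c2csc(N/N=C(\C)c3ccco3)n2)c1` has not yet been measured. It differs from compound 1 in one place: furan-2-yl in place of hexyl on a carbon with a double bond to nitrogen. Going by the values given here, one measured step bears on this change. Going from compound 2 to compound 3, a group holding one five-membered aromatic ring with one hetero atom, attached on a nitrogen on an aromatic ring, gives way to an open chain, and this assay moves by a 1.8-fold higher number from compound 2 to compound 3 (0.26 log units; within the scatter). The change from compound 1 to compound 4 runs the other way, an open chain giving way to a five-membered aromatic ring, so if anything the number is expected to fall, and by no more than that single step would suggest, staying within the scatter. Compound 4 is therefore expected to show a step of a 1.8-fold lower number from compound 1 to compound 4 (0.26 log units; within the scatter). The value of compound 4 in this assay is estimated at 750 nM, with a likely range from 300 nM to 1800 nM.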

Compound 4, half-maximal inhibitory concentration: 333 nM
Beside the measured number, compound 4's estimate is 2.3-fold (0.35 log units) above it; low and high end bracket the measured number.
By their numbers in this assay, from the lowest: compounds 4, 2, 3 and 1 (each within the scatter of the next, the first and the last beyond it).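

In this assay, furan-2-yl in place of hexyl on a carbon with a double bond to nitrogen gives a 4.1-fold lower number from compound 1 to compound 4 (0.62 log units; beyond the scatter) and so a modest step that the scatter does not cover. The earlier exchange of a five-membered aromatic ring for an open chain, with a 1.8-fold higher number from compound 2 to compound 3 (0.26 log units; within the scatter), could not show this, so the present change is the first among those shown to establish that the group at this position can shift the number. No available evidence accounts for the size of this step or says what about furan-2-yl lies behind it.

Hexyl and furan-2-yl differ both in the presence of a ring and in the hetero atom they carry, so this one step cannot separate the two, and it remains open whether a shorter chain such as butyl would fall with the ring compounds or stay with compound 1. Also open, on these data alone, is how a saturated ring such as cyclohexyl or tetrahydrofuran-2-yl, or a phenyl ring, would read on the same carbon.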